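Ring-nitrogen aryl swap in the thiazolidinone amide series

The source may report more compounds than this note shows. Statements on the series, on what has been measured and on what is new or still open speak of the compounds shown alone.

Three compounds have been run through a functional assay on HOS-TE85 cells (Homo sapiens) for inhibition, read by CCK-8 assay, with a stated time of 72 h, tested at 1 uM; a higher number here means more inhibition at the concentration tested (going by the name of the read-out), a lower number less inhibition. Compound 1 `COc1ccccc1N1C(=O)CSC1c1cc(F)cc(C(=O)O)c1` gives 0% in this assay. Among the compounds with values here, compound 2 `COc1cccc(OC)c1N1C(=O)CSC1c1cccc(C(=O)NCCCCc2ccccc2)c1` gives 95%, the highest of the three numbers so far; its nearest neighbour is compound 3 `O=C(NCCCCc1ccccc1)c1cccc(C2OCC(=O)N2c2cccc(F)c2)c1`, which gives 87%, a gap that lies within the scatter, while compound 1 stands far below it, beyond the scatter. Within the data shown here, no pair of measured compounds differs in only one place, so no single-point step is available yet.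

The next compound, compound 4 `CC(F)(F)c1cccc(N2C(=O)CSC2c2cccc(C(=O)NCCCCc3ccccc3)c2)c1`, differs from compound 2 in one place: a group of 10 heavy atoms (8 carbon, 2 fluorine; one six-membered aromatic ring of carbon only) in place of a group of 10 heavy atoms (8 carbon, 2 oxygen; one six-membered aromatic ring of carbon only), on an amide-type nitrogen in a ring. The amide chain shared by compound 2 and compound 3 is kept.

Since compound 2 and compound 3 both give high numbers in this assay with different groups on that amide-type nitrogen in a ring, the step from compound 2 to compound 4 is expected to be small, most likely a modest decrease that may stay within the scatter, estimated as a number 15 percentage points lower from compound 2 to compound 4 (beyond the scatter). Compound 4 is accordingly expected to give about 80% in this assay, within a range of 50% to 95%.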

Compound 4, a percentage reported as inhibition, at one concentration (the size of the read-out at that concentration, not a potency): 93%
Estimate against measurement, compound 4: 13 percentage points below; the measured number falls inside the stated range.
By their numbers in this assay, from the lowest: compound 1; then compounds 3, 4 and 2 (each within the scatter of the next).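

Within the data shown here, this is the first one-place comparison. At the amide-type nitrogen in a ring, the 2,6-dimethoxyphenyl group gives way to a group of equal heavy-atom count with fluorine in place of oxygen and no hydrogen-bond acceptors, and this assay reads a number 2 percentage points lower from compound 2 to compound 4 (within the scatter), so the two oxygens of the leaving group are not needed at this position for a high number at the single concentration tested. No measurement is available that bears on why the two compounds read alike.

A single-concentration read-out with both compounds high gives no potency, so any difference between them at lower concentrations stays hidden. On these data alone, whether an amine on that aromatic ring, or a longer chain on the amide, would keep the number also remains open.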